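Changing the propyl chain of compound 3

The source may report more compounds than this note shows. Statements on the series, on what has been measured and on what is new or still open speak of the compounds shown alone.

- Compound 1 `COc1cc(C(=O)n2ccc3ccccc32)cc(OC)c1OC` gives > 10000 nM as a limit of the assay
- Compound 2 `COc1cc(C(=O)c2cccc3[nH]ccc23)cc(OC)c1OC` gives 53.8 nM
- Compound 3 `CCCn1ccc2cc(C(=O)c3cc(OC)c(OC)c(OC)c3)ccc21` gives 2000 nM

All three compounds were tested in a functional assay on NCI-H460 cells (Homo sapiens) for inhibition, with a stated time of 72 h (a lower number here means a stronger inhibitor, a higher number a weaker inhibitor), and carry the same trimethoxyphenyl ketone portion, joined to the rest of each molecule in different ways. The value for compound 1 is a limit and not a number. Of the two true numbers, compound 3 has the higher (2000 nM) and compound 2 the lower (53.8 nM), and this gap lies beyond the usual scatter.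

The next compound to be measured is compound 4 `COc1cc(C(=O)c2ccc3c(ccn3CCN(C)C)c2)cc(OC)c1OC`. It keeps the shared core of compound 3 and changes only the end of the chain (dimethylamino in place of methyl on a saturated chain carbon, two bonds along the chain from an aromatic nitrogen): dimethylamino in place of methyl on a saturated chain carbon, two bonds along the chain from an aromatic nitrogen. Put another way, propyl becomes 2-(dimethylamino)ethyl.

Among the measured compounds shown here, no two measured compounds differ in one place alone, so no direct comparison sizes this change. The expectation therefore starts from compound 3 (2000 nM) and assumes no large shift in this assay. The estimated change is a 1.3-fold lower number from compound 3 to compound 4 (0.12 log units; within the scatter) and is expected to stay within the scatter. Compound 4 is expected at about 1500 nM with an estimated range from 400 nM to 6000 nM as its likely span.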

Compound 4, half-maximal inhibitory concentration: 5100 nM
The estimate for compound 4 lay 3.4-fold (0.53 log units) below the measured number; measured number inside the range.
By their numbers in this assay, from the lowest: compound 2; then compound 3; then compound 4. At a limit, above all of these: compound 1.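

In this assay, among the compounds shown here, replacing propyl with 2-(dimethylamino)ethyl gives a 2.6-fold higher number from compound 3 to compound 4 (0.41 log units; beyond the scatter), the first step in this set that sizes a single change. It shows that the end of the chain on the aromatic nitrogen is not a silent position: placing dimethylamino where methyl stood moves compound 4 towards a weaker inhibitor, modestly but beyond the usual scatter. Compound 4 still gives a true number, and the only entry that is a limit of the assay and not a number remains that of compound 1: the limit of > 10000 nM in this assay, at which 1 of the 4 values shown sits.

One step cannot tell whether the shift belongs to the amine nitrogen itself or simply to the larger group at the chain end, and a hydroxyl, a primary amine or a carboxylic acid at the same place, or a longer chain carrying the same dimethylamino, would be needed to separate these readings. For the compounds shown here, compound 1 and compound 2 differ from this pair in more than one place, so no steps to them can be read, and whether the same change would act alike on another core remains open.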